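Sulfur-to-selenium exchange on a bis-acylated isothiourea core

The compounds below may be only part of what the source reports. "The series", "measured", "known", "first", "only" and "open" are said of these compounds alone.

Two compounds of this series have numbers in a functional assay on K562 cells (Homo sapiens) for cytotoxicity, read by MTT assay, with a stated time of 72 h; on this read-out lower numbers stand for stronger inhibition of growth and higher numbers for weaker inhibition of growth. Compound 1 `CS/C(=N\C(=O)c1sccc1Cl)NC(=O)c1sccc1Cl` gives 78900 nM in this assay. Compound 2 `O=C(/N=C(/NC(=O)c1cc(-c2ccccc2)nc2ccccc12)[Se]Cc1ccccc1)c1cc(-c2ccccc2)nc2ccccc12`, built on a different core, gives 47400 nM in this assay. The two numbers lie within the usual scatter of each other, so neither compound can be set apart from the other on what is known.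

Compound 3 `C[Se]/C(=N\C(=O)c1sccc1Cl)NC(=O)c1sccc1Cl` is not yet measured. It differs from compound 1 by a group of 2 heavy atoms (1 carbon, 1 selenium; no ring) in place of a group of 2 heavy atoms (1 carbon, 1 sulfur; no ring), on a carbon with a double bond to nitrogen, with the remainder of the shared core of compound 1 unchanged. Among the measured compounds shown here, no measured pair shows what such an exchange does, so the expectation rests on compound 1 alone. The step of a 1.1-fold lower number from compound 1 to compound 3 (0.05 log units; within the scatter) is expected to stay within the scatter, in no particular direction. Compound 3 is therefore estimated at 70000 nM in this assay, with a range from 30000 nM to 160000 nM.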

Compound 3, concentration for total growth inhibition: 28500 nM
The estimate for compound 3 lay 2.5-fold (0.39 log units) above the measured number; the measured number lies below the stated range.
By their numbers in this assay, from the lowest: compounds 3, 2 and 1 (each within the scatter of the next, the first and the last beyond it).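

In this assay, among the compounds shown here, selenium in place of the sulfur of methylsulfanyl gives a 2.8-fold lower number from compound 1 to compound 3 (0.44 log units; beyond the scatter), the first exchange at a single place and a modest one. This position, on a carbon with a double bond to nitrogen, therefore responds to the exchange: with the remainder of the shared core unchanged, the number moves beyond the scatter towards stronger inhibition of growth. Nothing available gives a reason for this step.

Open, from the compounds shown here alone, is whether the same exchange gives a step of similar size on another core, such as that of compound 2. Also open, going by these compounds, is how an ethyl or longer chain on the selenium, or an amine on this carbon, would shift the number.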